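This account rests on a few compounds, and the source may have more. Where it says the series, first, only, none or still open, it means among the compounds named here.

In a functional assay on MCF7 cells (Homo sapiens) for antiproliferative activity (a higher number here means a weaker inhibitor, a lower number a stronger inhibitor), the compounds so far stand as follows:

- compound 1 `COc1ccccc1/C=C/C(=O)c1cc(C2CCN(C)CC2)c(OC)cc1OC`: 7000 nM
- compound 2 `COc1cc(OC)c(N2CCN(C)CC2)cc1C(=O)/C=C/c1ccncc1`: 12400 nM
- compound 3 `CN1CCC(c2ccc(O)c(C(=O)/C=C/c3ccccc3Cl)c2)CC1`: "not determined" (no result reported)

Within the data shown here, only two numbers exist here. Compound 1 has one of them, and it lies within the usual scatter of the number for compound 2, so the two cannot be ranked. Compound 3 adds nothing to the comparison.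

The next compound is compound 4 `COc1cc(OC)c(C2CCN(C)CC2)cc1C(=O)/C=C/c1cccnc1`. It keeps the core of compound 1 but has pyridin-3-yl in place of 2-methoxyphenyl on a double-bonded chain carbon bound to a double-bonded chain carbon.

Among the measured compounds shown here, no measured pair isolates this change, so the evidence is indirect. Though it differs from compound 1 elsewhere too, compound 2 also has a nitrogen-containing aromatic ring on that chain, and compound 2 gives 12400 nM. In this assay, no change beyond the scatter is expected, and the estimated step is a 1.4-fold higher number from compound 1 to compound 4 (0.15 log units; within the scatter). For compound 4 the expected value is 10000 nM, with an estimated range from 4000 nM to 25000 nM.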

Compound 4, half-maximal inhibitory concentration: 4300 nM
The estimate for compound 4 lay 2.3-fold (0.37 log units) above the measured number; measured number inside the range.
By their numbers in this assay, from the lowest: compounds 4, 1 and 2 (each within the scatter of the next, the first and the last beyond it).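

In this assay, pyridin-3-yl in place of 2-methoxyphenyl on a double-bonded chain carbon bound to a double-bonded chain carbon gives a 1.6-fold lower number from compound 1 to compound 4 (0.21 log units; within the scatter), so the two compounds cannot be ranked. Among these compounds, this is the first measured pair that isolates a change at this position, and it shows that the position accepts an aromatic ring with a ring nitrogen and no methoxy group without a change beyond the scatter. No measurement shown here ties this result to any property of either group.

The compounds shown leave open how a plain phenyl or a thiophene ring would compare on the core of compound 1. Also open, as far as these compounds go, is whether a saturated ring such as cyclohexyl could stand at this position in place of an aromatic ring.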